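A Hydroxyethyl Amide in Place of a Dimethyl Amide

The compounds below may be only part of what the source reports. "The series", "measured", "known", "first", "only" and "open" are said of these compounds alone.

In an ADME assay on J774 cells (Mus musculus) for cytotoxicity (on this read-out higher numbers stand for an effect only at larger amounts of compound and lower numbers for an effect already at smaller amounts), compound 1 (`CCCCc1cc2c(=O)cc[nH]c2cc1OCCOc1ccccc1`) reads > 20000 nM as a limit of the assay. Compound 2 (`CCCCc1cc2c(=O)c(C(=O)N(C)C)c[nH]c2cc1OCCOc1ccccc1`) gives 15300 nM, the only actual number shown. Compound 3 (`CCCCc1cc2c(=O)c(C(=O)NCCO)c[nH]c2cc1OCCOc1ccccc1`) carries (2-hydroxyethyl)amino in place of dimethylamino on a carbonyl carbon. Within the data shown here, only one measured step bears on this change (an at least 1.3-fold lower number from compound 1 to compound 2 (0.11 log units; that floor lies within the scatter)), the one that brought in dimethylcarbamoyl. On that basis the move expected in this assay stays within the scatter, with no clear direction (a 1.1-fold higher number from compound 2 to compound 3 (0.05 log units; within the scatter)). For compound 3 the estimated value is 17000 nM (expected range 8000 nM to 30000 nM).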

Compound 3, half-maximal effective concentration: > 20000 nM
Compound 3: a limit, no number; the forecaster's own chance of this, stated with the estimate: 35%; middle value at least 1.1-fold (0.07 log units) away from the limit.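

In this assay, as far as these compounds go, (2-hydroxyethyl)amino in place of dimethylamino on the carbonyl carbon gives an at least 1.3-fold higher number from compound 2 to compound 3 (0.11 log units; that floor lies within the scatter), so this change shows no move beyond the scatter, though its true size stays unknown. Compound 3 gives a limit rather than a number, and the step therefore has only a floor, set by the top of the read-out: the limit of > 20000 nM in this assay, at which 2 of the 3 values shown sit.

The step between compound 1 and compound 3 cannot be read. From the compounds shown here alone, whether an amine, a carboxylic acid or a longer chain on this carbonyl carbon would give a number within the range of the read-out remains open.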